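The source may hold more compounds than are shown below. What is called first, only, known or untested is meant among the compounds shown, and "the series" means these compounds.

Three compounds share one core and differ only in the group on a saturated chain carbon bound to a double-bonded chain carbon. In a functional assay on PC-3 cells (Homo sapiens) for antiproliferative activity, read by MTT assay, with a stated time of 72 h (a higher number here means a weaker inhibitor, a lower number a stronger inhibitor), compound 1 `CC/C=C/C(=O)Nc1cc2c(N3CCc4ccccc43)ncnc2cc1O[C@@H]1CCOC1` gives 9590 nM, compound 2 `CN(C)C/C=C/C(=O)Nc1cc2c(N3CCc4ccccc43)ncnc2cc1O[C@@H]1CCOC1` gives 1230 nM, and compound 3 `CCN(CC)C/C=C/C(=O)Nc1cc2c(N3CCc4ccccc43)ncnc2cc1O[C@@H]1CCOC1` gives 5780 nM. Compound 3 thus stands second highest of the three numbers, close to compound 1, since a 1.7-fold lower number from compound 1 to compound 3 (0.22 log units; within the scatter), and well apart from compound 2, since a 4.7-fold higher number from compound 2 to compound 3 (0.67 log units; beyond the scatter). Compound 4 `O=C(/C=C/CN1CCCCC1)Nc1cc2c(N3CCc4ccccc43)ncnc2cc1O[C@@H]1CCOC1` carries piperidin-1-yl in place of diethylamino on a saturated chain carbon bound to a double-bonded chain carbon. Among the measured compounds shown here, the steps that bear on it are the changes of the amine. One of them is a 7.8-fold lower number from compound 1 to compound 2 (0.89 log units; beyond the scatter). The other is the step from compound 2 to compound 3 already given. Closing the two ethyl groups into a six-membered ring is expected to give a modest lowering, a 2.3-fold lower number from compound 3 to compound 4 (0.36 log units; beyond the scatter). Compound 4 is therefore estimated at 2500 nM, within 900 nM to 7000 nM.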

Compound 4, half-maximal inhibitory concentration: 4510 nM
Compound 4: middle estimate off by 1.8-fold (0.26 log units), on the low side; low and high end bracket the measured number.
By their numbers in this assay, from the lowest: compound 2; then compounds 4, 3 and 1 (each within the scatter of the next, the first and the last beyond it).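

In this assay, closing the two ethyl groups of diethylamino into piperidin-1-yl leaves the two compounds within the scatter (a 1.3-fold lower number from compound 3 to compound 4 (0.11 log units; within the scatter)), so this ring does not set them apart. Compound 4 still stands clear of both the dimethylamino compound (a 3.7-fold higher number from compound 2 to compound 4 (0.56 log units; beyond the scatter)) and the compound with methyl at this place (a 2.1-fold lower number from compound 1 to compound 4 (0.33 log units; beyond the scatter)). No measurement shown here accounts for these steps. From the compounds shown here alone, whether pyrrolidin-1-yl, morpholin-4-yl or 4-methylpiperazin-1-yl would fall nearer compound 2 or compound 4 remains open.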